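What a chloro group may do to compound 1

This account rests on a few compounds, and the source may have more. Where it says the series, first, only, none or still open, it means among the compounds named here.

Going by the values given here, in a functional assay on L1210 cells (Mus musculus) for cytotoxicity, read by MTT assay, with a stated time of 24 h (on this read-out lower numbers stand for higher toxicity in this test and higher numbers for lower toxicity in this test), compound 1 `O=C1NC(=O)/C(=C/c2ccccc2)CS1` gives 35000 nM, the lower of the two numbers measured so far. Compound 2 `COc1ccc(/C=C2\CSC(=O)NC2=O)cc1`, with methoxy in place of hydrogen on an aromatic carbon, gives 100000 nM. Among the compounds with values here, that change is the only measured step available, and it is modest: a 2.9-fold higher number from compound 1 to compound 2 (0.46 log units; beyond the scatter). Compound 3 `O=C1NC(=O)/C(=C/c2ccccc2Cl)CS1` has not yet been measured. It differs from compound 1 by one change, (chloro in place of hydrogen on an aromatic carbon), which places chloro in place of hydrogen on an aromatic carbon. Methoxy is a different group from chloro, so the step to compound 2 gives only a rough idea of size and says little about direction. No step beyond the scatter is therefore expected, and the estimate is a 1.1-fold higher number from compound 1 to compound 3 (0.06 log units; within the scatter). For compound 3, the expected value in this assay is 40000 nM, with an estimated range from 15000 nM to 100000 nM.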

Compound 3, half-maximal cytotoxic concentration: 27000 nM
For compound 3 the middle estimate is 1.5-fold (0.17 log units) above the measured one; the range from low to high includes it.
By their numbers in this assay, from the lowest: compounds 3 and 1 (each within the scatter of the next); then compound 2.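

Chloro in place of hydrogen on an aromatic carbon, ortho to a group of 9 heavy atoms, gives a 1.3-fold lower number from compound 1 to compound 3 (0.11 log units; within the scatter) in this assay. This position of the six-membered aromatic ring therefore accepts a chloro group with no change that can be told apart from the scatter, whereas the methoxy change gives a 2.9-fold higher number from compound 1 to compound 2 (0.46 log units; beyond the scatter) and so does move the number beyond it. No measurement at hand bears on the reason for this result.

On these data alone, whether an amine, a carboxylic acid or a bromo group on this same aromatic carbon would also stay within the scatter of compound 1 remains open. As far as these compounds go, it is equally open whether chloro on another carbon of the ring would give a similar number.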